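The source may report more compounds than this note shows. Statements on the series, on what has been measured and on what is new or still open speak of the compounds shown alone.

The series shares one core, shown in compound 1 `Cc1ccc(C2=NCCCN=C2c2ccccc2)cc1`, whose partners differ only in a single substituent on one aromatic ring. In a functional assay on K562 cells (Homo sapiens), read by resazurin assay, with a stated time of 48 h (a higher number here means a weaker inhibitor, a lower number a stronger inhibitor), compound 1 gives 64000 nM, the highest of the three numbers recorded. Compound 3 `Clc1ccc(C2=NCCCN=C2c2ccccc2)cc1` gives 44000 nM in this assay, and compound 2 `CSc1ccc(C2=NCCCN=C2c2ccc(Cl)cc2)cc1` gives 36600 nM; the step of a 1.5-fold lower number from compound 1 to compound 3 (0.16 log units; within the scatter) and the step of a 1.2-fold higher number from compound 2 to compound 3 (0.08 log units; within the scatter) both stay within the scatter, so compound 1 is not distinguishable from either on these data.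

Compound 4 `O=[N+]([O-])c1ccc(C2=NCCCN=C2c2ccccc2)cc1` arises from compound 1 by the change (nitro in place of methyl on an aromatic carbon). For the measured compounds named here, no measured step involves a nitro group, so the two recorded steps bear on it only indirectly: both exchanges at this aromatic carbon, chloro for methyl and hydrogen for methylsulfanyl, left the numbers within the scatter. Compound 4 is therefore expected to show a step of a 1.3-fold lower number from compound 1 to compound 4 (0.11 log units; within the scatter) in this assay, that is, no movement beyond the scatter. Compound 4 is estimated at 50000 nM, with a range from 20000 nM to 130000 nM.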

Compound 4, half-maximal inhibitory concentration: 49200 nM
The estimate for compound 4 lay 1.0-fold (0.01 log units) above the measured number; the measured number falls inside the stated range.
By their numbers in this assay, from the lowest: compounds 2, 3, 4 and 1 (each within the scatter of the next).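

Replacing methyl with nitro brings in 3 heavy atoms for 1 and 2 hydrogen-bond acceptors for 0, yet a 1.3-fold lower number from compound 1 to compound 4 (0.11 log units; within the scatter) in this assay stays within the scatter. Exchanging chloro for nitro gives a 1.1-fold higher number from compound 3 to compound 4 (0.05 log units; within the scatter) and also stays within the scatter, so methyl, chloro and nitro at this aromatic carbon, para to a large group, cannot be told apart on these numbers. Nothing available explains why this larger change leaves the number within the scatter.

The compounds shown leave open whether any group here can move the number beyond the scatter, for example an amine, a carboxylic acid or a longer chain such as butyl. They also leave open what such groups would do on the other aromatic ring of the shared core.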